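Cytotoxicity of Compound 4: Guided by Three Limits

This account rests on a few compounds, and the source may have more. Where it says the series, first, only, none or still open, it means among the compounds named here.

Of the compounds shown here, three sharing one core have been tested in an ADME assay on L929 cells (Mus musculus) for cytotoxicity, read by resazurin assay, with a stated time of 72 h; a higher number here means a weaker inhibitor, a lower number a stronger inhibitor. Compound 1 `O=C(/C=C/c1ccc2c(c1)B(O)OC2)c1cccc(F)c1` gives > 10 ug/mL, which is a limit of the assay rather than a number. Compound 2 `Nc1ccc(C(=O)/C=C/c2ccc3c(c2)B(O)OC3)cc1` gives > 10 ug/mL, again a limit. Compound 3 `Cn1cccc1C(=O)/C=C/c1ccc2c(c1)B(O)OC2` gives > 10 ug/mL, also a limit. Because all three sit at the limit of > 10 ug/mL in this assay, at which 3 of the 3 values shown sit, none of the connecting steps can be sized: a step that the two limits leave unreadable from compound 1 to compound 2, a step that the two limits leave unreadable from compound 1 to compound 3 and a step that the two limits leave unreadable from compound 2 to compound 3 are all unreadable. Compound 3 thus stands level with its two companions at the limit, with no numbered value to place it more precisely.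

Compound 4 `O=C(/C=C/c1ccc2c(c1)B(O)OC2)c1ccccc1F` differs from compound 3 in one place: 2-fluorophenyl in place of 1-methyl-1H-pyrrol-2-yl on a carbonyl carbon. Compound 1 already carries 3-fluorophenyl on the same carbonyl carbon and reaches only the limit, and the unreadable steps give no direction either way. The step in this assay is therefore expected to be small or absent: a step that the limit leaves unreadable from compound 3 to compound 4. Compound 4 is estimated at 20 ug/mL, within 8 ug/mL to 60 ug/mL, and most likely reported once more as a limit.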

Compound 4, half-maximal inhibitory concentration: > 10 ug/mL
Compound 4 was reported as a limit; the forecaster's own chance of this, stated with the estimate: 80%; the middle value lies beyond the limit too.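

Going by these compounds alone, compound 4 is reported only as a limit, as are compound 1, compound 2 and compound 3, so no step among them can be read in this assay: the limit of > 10 ug/mL in this assay, at which 4 of the 4 values shown sit. The compounds shown leave open where each of the four truly lies beyond that limit, and whether their different groups on the carbonyl carbon change the result at all.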